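Swapping Morpholine for Piperidine on a Succinate Ester

The source may hold more compounds than are shown below. What is called first, only, known or untested is meant among the compounds shown, and "the series" means these compounds.

Measured so far in an assay on isolated protein for inhibition of glutathione S-transferase Mu 2 (Homo sapiens), with a stated time of 10 min; on this read-out higher numbers stand for weaker inhibition and lower numbers for stronger inhibition:
compound 1 `O=C(CCC(=O)OCCCCCCSc1ccc([N+](=O)[O-])c2nonc12)Nc1ccc(F)c(Cl)c1` gives 470 nM
compound 2 `O=C(CCC(=O)N1CCOCC1)OCCCCCCSc1ccc([N+](=O)[O-])c2nonc12` gives 170 nM

Compound 2 holds the lowest number of the two, set apart from compound 1 by a 2.8-fold lower number from compound 1 to compound 2 (0.44 log units; beyond the scatter). Compound 3 `O=C(CCC(=O)N1CCCCC1)OCCCCCCSc1ccc([N+](=O)[O-])c2nonc12` is not yet measured; it differs from compound 2 by piperidin-1-yl in place of morpholin-4-yl on a carbonyl carbon. Among the measured compounds shown here, the single measured step concerned a different group, not the ring in question, so nothing in these data bears directly on a morpholine-to-piperidine swap. With no guidance either way, the expected step is no change at the digits printed from compound 2 to compound 3 (within the scatter). Compound 3 is therefore estimated at 170 nM, within 70 nM to 420 nM.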

Compound 3, half-maximal inhibitory concentration: 110 nM
For compound 3 the middle estimate is 1.5-fold (0.19 log units) above the measured one, within the range that was stated.
By their numbers in this assay, from the lowest: compounds 3 and 2 (each within the scatter of the next); then compound 1.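

Piperidin-1-yl in place of morpholin-4-yl on the carbonyl carbon gives a 1.5-fold lower number from compound 2 to compound 3 (0.19 log units; within the scatter), so this assay cannot tell these two rings apart. Piperidin-1-yl in place of the (3-chloro-4-fluorophenyl)amino group gives a 4.3-fold lower number from compound 1 to compound 3 (0.63 log units; beyond the scatter), so a second saturated ring at this position also reads lower than that group. Nothing available explains these numbers.

Going by these compounds, whether a ring is needed here at all remains open. A dimethylamino group, a pyrrolidine ring or a free carboxylic acid on the same carbonyl carbon could help to settle that.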